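A few compounds are considered here, and "the series" means these few. Any claim that something is new, unique, unknown or untested is made for them only; others in the source may bear on it.

Measured so far:
- compound 1 `CCCC[C@]1(CC)CS(=O)(=O)c2ccc(OC)cc2[C@@H](c2ccccc2)[C@H]1O`: 55 nM
- compound 2 `CCCC[C@]1(CC)CS(=O)(=O)c2cc(O)ccc2[C@@H](c2ccccc2)[C@H]1O`: 90 nM

In an assay on cells for inhibition of ileal sodium/bile acid cotransporter (Homo sapiens) (on this read-out lower numbers stand for stronger inhibition and higher numbers for weaker inhibition), compound 1 gives 55 nM, the lower of the two numbers recorded; compound 2 gives 90 nM, and the gap between them sits within the scatter, so neither is set apart. Within the data shown here, no step between measured compounds has been worked out. Compound 3 `CCCC[C@]1(CC)CS(=O)(=O)c2ccc(N(O)C(=O)OC(C)(C)C)cc2[C@@H](c2ccccc2)[C@H]1O` is not yet measured; it differs from compound 1 as follows: hydroxy(tert-butoxycarbonyl)amino in place of methoxy on an aromatic carbon. A moderate step upward, toward weaker inhibition, is expected in this assay, beyond the scatter, with the estimated step being a 2.9-fold higher number from compound 1 to compound 3 (0.46 log units; beyond the scatter). Compound 3 is expected to give about 160 nM, in the range 45 nM to 600 nM.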

Compound 3, half-maximal inhibitory concentration: 2670 nM
Compound 3: middle estimate off by 17-fold (1.22 log units), on the low side; measured number outside the range, above it.
By their numbers in this assay, from the lowest: compounds 1 and 2 (each within the scatter of the next); then compound 3.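

In this assay, this aromatic carbon does not tolerate every replacement of methoxy: putting hydroxy(tert-butoxycarbonyl)amino there gives a 49-fold higher number from compound 1 to compound 3 (1.69 log units; beyond the scatter), a large step beyond the scatter. Among these compounds, this is the first step read, and it shows that the activity of the core of compound 1 depends on the group at this place. Nothing available accounts for the step.

The compounds shown do not separate the contribution of the hydroxy on nitrogen from that of the tert-butoxycarbonyl. On these data alone, how a plain amine or a carboxylic acid at this carbon would read also remains open.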